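Cytotoxicity notes on the imidazolylmethyl-aniline series

The source may hold more compounds than are shown below. What is called first, only, known or untested is meant among the compounds shown, and "the series" means these compounds.

Compound 1 `CCC(=O)c1ccc(NCc2cncn2Cc2ccc(-c3ccccc3)cc2)cc1-c1ccccc1` is tested in a toxicity assay on NIH3T3 cells (Mus musculus) for cytotoxicity, read by resazurin assay (on this read-out lower numbers stand for an effect already at smaller amounts and higher numbers for an effect only at larger amounts of compound), and gives > 10000 nM, which is a limit of the assay and not a number. Compound 2 `Cc1cccc(-c2cccc(NCc3cncn3Cc3ccccc3)c2)c1` gives > 1000 nM in this assay, again a limit. Compound 3 `Cc1cccc(-c2cc(NCc3cncn3Cc3ccc(-c4ccccc4)cc3)ccc2-c2nc3ccccc3s2)c1C` gives > 1000 nM in this assay, also a limit. Thus compound 1 sits at the limit of > 10000 nM in this assay, at which 1 of the 3 values shown sits, while the other two sit at the limit of > 1000 nM in this assay, at which 2 of the 3 values shown sit; no measured value is a number, so no step between measured compounds can be sized.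

Compound 4 `COc1ccc(NCc2cncn2Cc2ccc(-c3ccccc3)cc2)cc1-c1ccccc1` differs from compound 1 by methoxy in place of propanoyl on an aromatic carbon. No step beyond the scatter is expected in this assay for this change, in either direction. Compound 4 is therefore expected to show 15000 nM, between 4000 nM and 60000 nM, most likely again as a limit, the expected step being a step that the limit leaves unreadable from compound 1 to compound 4.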

Compound 4, half-maximal effective concentration: > 1000 nM
Compound 4 ended at the assay's limit (the forecaster's own chance of this, stated with the estimate: 80%); the middle value does not contradict the limit.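

Compound 1 and compound 4 both stand at limits of the assay, so no step can be read for methoxy in place of propanoyl. The compounds shown leave open at what concentration, if any, cytotoxicity appears.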